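Swapping dimethylamino for acetyl on the shared core

The source may report more compounds than this note shows. Statements on the series, on what has been measured and on what is new or still open speak of the compounds shown alone.

Compound 1 `COc1cc(C)cc(-c2c(-c3ccnc(-c4ccc(N(C)C)cc4)c3)cnn2CC#N)c1` gives 37% in a functional assay on SK-OV-3 cells (Homo sapiens) for cytotoxicity, read by sulforhodamine B assay, with a stated time of 48 h, tested at 100 nM; on this read-out lower numbers stand for a stronger effect and higher numbers for a weaker effect at the one concentration tested.
Compound 2 `COc1cc(C)cc(-c2nn(CC#N)cc2-c2ccc(-c3cccc(C(C)=O)c3)nc2)c1` gives 104% in this assay.

Compound 1 has the lowest of the two numbers, so the stronger effect; the number for compound 2 sits well beyond the scatter above it. Compound 3 `COc1cc(C)cc(-c2c(-c3ccnc(-c4ccc(C(C)=O)cc4)c3)cnn2CC#N)c1` differs from compound 1 in one place: acetyl in place of dimethylamino on an aromatic carbon. For the measured compounds named here, no measured pair shows this exact change. Compound 2 also carries an acetyl group and gives a high number, which hints that the step from compound 1 to compound 3 is expected to weaken the effect, a number 38 percentage points higher from compound 1 to compound 3 (beyond the scatter). Compound 3 is therefore estimated at 75%, within a range of 40% to 105%.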

Compound 3, a percentage reported as activity, at one concentration (the size of the read-out at that concentration, not a potency): 102%
The estimate for compound 3 lay 27 percentage points below the measured number; measured number inside the range.
By their numbers in this assay, from the lowest: compound 1; then compounds 3 and 2 (each within the scatter of the next).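

For the compounds shown here, with 4-(dimethylamino)phenyl changed to 4-acetylphenyl on the shared core, this assay records a number 65 percentage points higher from compound 1 to compound 3 (beyond the scatter) as the only change between the two structures. Going by these compounds alone, this ties a large loss of effect at the concentration tested to this one position, which the earlier compounds, differing in more than one place, could not do. Nothing available explains why this swap has such an effect.

As far as these compounds go, it remains open whether a plain amino group, a morpholine ring or a carboxylic acid at this position would keep the effect of compound 1. Whether other groups there would give a still lower number is also unknown.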